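Trading Ethyl for 4-Fluorophenyl on the Shared Core

A few compounds are considered here, and "the series" means these few. Any claim that something is new, unique, unknown or untested is made for them only; others in the source may bear on it.

Compound 1 `CCC(c1ccccc1)c1nc(-c2ccc(Cl)cc2)c(CC(=O)O)s1` sits at a limit of an in vitro functional assay on HEK285-7 cells for antagonist activity at prostaglandin D2 receptor 2 (Homo sapiens), read by BRET and beta-arrestin recruitment (a lower number here means a stronger inhibitor, a higher number a weaker inhibitor), reported as > 100000 nM, so it gives only a limit and no number (the limit of > 100000 nM in this assay, at which 1 of the 3 values shown sits). Within the data shown here, compound 2 `O=C(O)Cc1sc(CSc2ccccc2)nc1-c1ccc(Cl)cc1` gives 450 nM in this assay, and compound 3 `O=C(O)Cc1sc(COc2ccc(Cl)cc2)nc1-c1ccc(Cl)cc1` gives 370 nM; the one measured step, a 1.2-fold lower number from compound 2 to compound 3 (0.09 log units; within the scatter), lies within the scatter. Compound 4 `O=C(O)Cc1sc(C(c2ccccc2)c2ccc(F)cc2)nc1-c1ccc(Cl)cc1` differs from compound 1 by 4-fluorophenyl in place of ethyl on a saturated chain carbon bound to two aromatic carbons. Among the measured compounds shown here, no measured step touches that saturated chain carbon, and the step from compound 2 to compound 3 concerns another part of the core, so it offers no direct guide. Compound 4 is therefore expected, with wide uncertainty, to move by an at least 33-fold lower number from compound 1 to compound 4 (1.52 log units; beyond the scatter), and its estimated value is 3000 nM, within a range of 200 nM to 100000 nM.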

Compound 4, half-maximal inhibitory concentration: 36 nM
For compound 4 the middle estimate is 83-fold (1.92 log units) above the measured one; the measured number lies below the stated range.
By their numbers in this assay, from the lowest: compound 4; then compounds 3 and 2 (each within the scatter of the next). At a limit, above all of these: compound 1.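

Among these compounds, at the saturated chain carbon bound to two aromatic carbons, 4-fluorophenyl in place of ethyl gives an at least 2700-fold lower number from compound 1 to compound 4 (3.44 log units; beyond the scatter), so this position responds strongly to this one change, which the step among the earlier compounds does not touch. The size of that step is only a bound, since compound 1 stands at a limit: the limit of > 100000 nM in this assay, at which 1 of the 4 values shown sits.

Open, on these data alone, is how much of the step belongs to the six-membered aromatic ring and how much to its fluorine, a question that a plain phenyl on this carbon would address. Also open, as far as these compounds go, is whether a smaller group, such as methyl or hydroxyl, would be tolerated there.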